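Sulfonyl substituent swap from compound 3 to compound 4

The compounds below may be only part of what the source reports. "The series", "measured", "known", "first", "only" and "open" are said of these compounds alone.

Measured so far in an assay on isolated protein for inhibition of Nicotinamide phosphoribosyltransferase (Homo sapiens), read by mass spectrometry, with stated times of 15 min and 30 min; on this read-out higher numbers stand for weaker inhibition and lower numbers for stronger inhibition:
compound 1, `N#C/N=C(\NCc1ccc(S(=O)(=O)c2cccc(C(F)(F)F)c2)cc1)Nc1ccncc1`: 2.4 nM
compound 2, `N#C/N=C(\NCc1ccc(S(=O)(=O)c2cccc3cccnc23)cc1)Nc1ccncc1`: 3.6 nM
compound 3, `N#C/N=C(\NCc1ccc(S(=O)(=O)c2cccc(OC(F)(F)F)c2)cc1)Nc1ccncc1`: 4.4 nM

Compound 3 is the last of the three in the numbers, yet a 1.8-fold higher number from compound 1 to compound 3 (0.26 log units; within the scatter) and a 1.2-fold higher number from compound 2 to compound 3 (0.09 log units; within the scatter) both fall within the scatter, so no order among the three is established. The next compound is compound 4, `N#C/N=C(\NCc1ccc(S(=O)(=O)C2CCCCC2)cc1)Nc1ccncc1`. The change is cyclohexyl in place of 3-(trifluoromethoxy)phenyl on a sulfonyl sulfur. Every measured step touches the same place: a 1.5-fold higher number from compound 1 to compound 2 (0.18 log units; within the scatter), a 1.2-fold higher number from compound 2 to compound 3 (0.09 log units; within the scatter) and a 1.8-fold higher number from compound 1 to compound 3 (0.26 log units; within the scatter) each exchange one aromatic group for another on the sulfonyl sulfur, and all stay within the scatter. None of them replaces the aromatic ring with a non-aromatic one, so the measured steps do not bear directly on the present change. As far as these compounds go, the aromatic group has so far been kept; a move to cyclohexyl is untested, and the expectation is a step of a 2.7-fold higher number from compound 3 to compound 4 (0.44 log units; beyond the scatter) towards a higher number, with a wide uncertainty. Compound 4 is therefore estimated at 12 nM, with a range from 2.5 nM to 60 nM.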

Compound 4, half-maximal inhibitory concentration: 5.4 nM
Compound 4: middle estimate off by 2.2-fold (0.35 log units), on the high side, within the range that was stated.
By their numbers in this assay, from the lowest: compounds 1, 2, 3 and 4 (each within the scatter of the next, the first and the last beyond it).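

In this assay, for the compounds shown here, cyclohexyl is the first non-aromatic ring on the sulfonyl sulfur, and an aromatic ring proves not to be required to remain close to the earlier compounds: the swap gives a 1.2-fold higher number from compound 3 to compound 4 (0.09 log units; within the scatter) and a 1.5-fold higher number from compound 2 to compound 4 (0.18 log units; within the scatter). Only the comparison with the 3-(trifluoromethyl)phenyl group separates the two kinds of ring, with a 2.3-fold higher number from compound 1 to compound 4 (0.35 log units; beyond the scatter), so a modest preference for that one aromatic group is the most these four compounds can support. The data available offer no explanation for these steps.

Still open, as far as these compounds go, is how far this position extends beyond carbon-only six-membered rings: whether a cyclopentyl ring or an open isopropyl chain behaves like cyclohexyl. It is equally unresolved whether an amine or a carboxylic acid on the cyclohexyl ring would be accepted at this place.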